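Swapping the aryl group on the amide: compound 4

The compounds below may be only part of what the source reports. "The series", "measured", "known", "first", "only" and "open" are said of these compounds alone.

Three analogues sharing one core have been measured in an assay on isolated protein for inhibition of glutathione S-transferase Mu 2 (Homo sapiens), with a stated time of 10 min; on this read-out higher numbers stand for weaker inhibition and lower numbers for stronger inhibition. Compound 1 `O=C(CCC(=O)OCCCCCCSc1ccc([N+](=O)[O-])c2nonc12)Nc1ccccc1F` gives 350 nM, compound 2 `COc1ccccc1NC(=O)CCC(=O)OCCCCCCSc1ccc([N+](=O)[O-])c2nonc12` gives 280 nM, and compound 3 `O=C(CCC(=O)OCCCCCCSc1ccc([N+](=O)[O-])c2nonc12)Nc1ccc(F)cc1` gives 320 nM. Compound 2 has the lowest of these three numbers, yet its gaps to compound 3 and compound 1 both lie within the scatter. Compound 4 `Cc1ccc(NC(=O)CCC(=O)OCCCCCCSc2ccc([N+](=O)[O-])c3nonc23)cc1` differs from compound 2 by 4-methylphenyl in place of 2-methoxyphenyl on an amide-type nitrogen. The steps of a 1.1-fold higher number from compound 2 to compound 3 (0.06 log units; within the scatter), a 1.1-fold lower number from compound 1 to compound 3 (0.04 log units; within the scatter) and a 1.3-fold lower number from compound 1 to compound 2 (0.10 log units; within the scatter) all stayed within the scatter, so for this change no step beyond the scatter is expected in this assay, in either direction. Compound 4 is therefore expected to give about 300 nM, within 150 nM to 600 nM, a step of a 1.1-fold higher number from compound 2 to compound 4 (0.03 log units; within the scatter).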

Compound 4, half-maximal inhibitory concentration: 390 nM
Compound 4: the middle estimate sits 1.3-fold (0.11 log units) below what was measured; low and high end bracket the measured number.
By their numbers in this assay, from the lowest: compounds 2, 3, 1 and 4 (each within the scatter of the next).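

Methyl now joins fluoro and methoxy as a substituent on the aryl group at this amide-type nitrogen, and in this assay every new step stays within the scatter (a 1.4-fold higher number from compound 2 to compound 4 (0.14 log units; within the scatter)) (a 1.2-fold higher number from compound 3 to compound 4 (0.09 log units; within the scatter)) (a 1.1-fold higher number from compound 1 to compound 4 (0.05 log units; within the scatter)). The 4-methylphenyl group, with no hydrogen-bond acceptor, therefore sits within the scatter of the 2-methoxyphenyl group, which has one. No supporting data bear on these results. The compounds shown leave open whether an aryl group carrying an amine or a carboxylic acid would step beyond the scatter.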